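Factor X binding series: sulfonamide lactams, rearranged bicyclic arm

A few compounds are considered here, and "the series" means these few. Any claim that something is new, unique, unknown or untested is made for them only; others in the source may bear on it.

Measured in an assay on isolated protein for inhibition of coagulation factor X (Oryctolagus cuniculus), tested at 1 uM; a lower number here means less inhibition, a higher number more inhibition at the concentration tested (going by the name of the read-out):
compound 1 `CC(C)(C)c1ccc(S(=O)(=O)N[C@H]2CCN(Cc3cc4cc[nH]cc-4n3)C2=O)cc1`: 57%
compound 2 `O=C1[C@@H](NS(=O)(=O)c2cc3c(Cl)nccc3s2)CCN1CCNc1ccncc1`: 39%
compound 3 `O=C1[C@@H](NS(=O)(=O)c2cc3c(Cl)nccc3s2)CCN1Cc1cc2c[nH]ccc-2n1`: 35%

Compound 3 gives the lowest of the three numbers in this assay; compound 2 sits within the scatter of it, and only compound 1 lies beyond the scatter above it. Among the compounds with values here, the one measured step, a number 4 percentage points lower from compound 2 to compound 3 (within the scatter), concerns the group on the saturated chain carbon bound to the amide-type nitrogen, not the part changed here.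

Compound 4 `O=C1[C@@H](NS(=O)(=O)c2cc3nc(Cl)ccc3s2)CCN1Cc1cc2c[nH]ccc-2n1` differs from compound 3 by a group of 10 heavy atoms (7 carbon, 1 nitrogen, 1 sulfur, 1 chlorine; one five-membered aromatic ring with 1 hetero atom, one six-membered aromatic ring with 1 hetero atom) in place of a group of 10 heavy atoms (7 carbon, 1 nitrogen, 1 sulfur, 1 chlorine; one five-membered aromatic ring with 1 hetero atom, one six-membered aromatic ring with 1 hetero atom), on a sulfonyl sulfur; the two have the same atoms, joined differently, on a sulfonyl sulfur whose other neighbours are: sulfonamide nitrogen. Within the data shown here, no measured step touches this place, so the direction cannot be read from the data. For compound 4 the step is expected to be no change at the digits printed from compound 3 to compound 4 (within the scatter), essentially no change beyond the scatter. Compound 4 is therefore estimated at 35%, with a range from 15% to 60%.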

Compound 4, a percentage reported as inhibition, at one concentration (the size of the read-out at that concentration, not a potency): 58%
Estimate against measurement, compound 4: 23 percentage points below; measured number inside the range.
By their numbers in this assay, from the lowest: compounds 3 and 2 (each within the scatter of the next); then compounds 1 and 4 (each within the scatter of the next).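

Within the data shown here, at the sulfonyl sulfur, the same atoms joined differently do not behave alike in this assay: the change gives a number 23 percentage points higher from compound 3 to compound 4 (beyond the scatter), the first measured step at this place. The counts of heavy atoms, donors and acceptors in the group stay the same, so this step shows that the arrangement alone can move the number beyond the scatter. No measurement at hand bears on the reason for this result.

Open, from the compounds shown here alone, is whether the chlorine of compound 4 matters, which a methyl or nitrile there would test. Also open, going by these compounds, is whether the step carries over to the arm of compound 2.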